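This account rests on a few compounds, and the source may have more. Where it says the series, first, only, none or still open, it means among the compounds named here.

Of the compounds shown here, three from this series have been tested in an assay on membranes from CHO cells for displacement of a labelled ligand from adenosine receptor A1 (Homo sapiens), read by scintillation counting, with a stated time of 60 min, tested at 1 uM; a higher number here means more inhibition at the concentration tested (going by the name of the read-out), a lower number less inhibition. Compound 1 `CC1=C(C(=O)OCc2ccccc2)C(c2cccs2)NC(=O)N1` gives 45% in this assay. Compound 2 `CC1=C(C(=O)C2CC2)C(c2cccs2)NC(=O)N1` gives 1%, and compound 3 `CCNC(=O)C1=C(C)NC(=O)NC1c1cccs1` gives 1%. Compound 3 thus stands level with compound 2 at the digits shown, the two together being the lowest of the three numbers, and it lies well under compound 1. Among the measured compounds shown here, the one single-point step measured so far, no change at the digits printed from compound 2 to compound 3 (within the scatter), shows no change within the scatter.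

Compound 4 `CC1=C(C(=O)OC2CCC2)C(c2cccs2)NC(=O)N1` is the next compound, not yet measured. It differs from compound 3 as follows: cyclobutyloxy in place of ethylamino on a carbonyl carbon. For the measured compounds named here, no measured step matches this change; the only one measured, from compound 2 to compound 3, swaps groups on the same carbonyl carbon and is flat. The two values show that compound 1, which also carries an ester at that carbonyl, gives 45%, while compound 3 gives 1%, so an ester may sit higher. Compound 4 is therefore expected to rise by a number 19 percentage points higher from compound 3 to compound 4 (beyond the scatter). Compound 4 is estimated at 20%, with a range from 0% to 50%.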

Compound 4, a percentage reported as inhibition, at one concentration (the size of the read-out at that concentration, not a potency): 24%
Compound 4: the middle estimate sits 4 percentage points below what was measured, within the range that was stated.
By their numbers in this assay, from the lowest: compounds 2 and 3 (each within the scatter of the next); then compound 4; then compound 1.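

In this assay the group on the carbonyl carbon now makes a difference: cyclobutyloxy in place of ethylamino gives a number 23 percentage points higher from compound 3 to compound 4 (beyond the scatter) and cyclobutyloxy in place of cyclopropyl gives a number 23 percentage points higher from compound 2 to compound 4 (beyond the scatter), whereas the earlier swap at this carbon gave no change at the digits printed from compound 2 to compound 3 (within the scatter). The ester alone does not set the number, for among the two esters cyclobutyl in place of benzyl on an oxygen next to a carbonyl group gives a number 21 percentage points lower from compound 1 to compound 4 (beyond the scatter). No measurement shown here accounts for these steps.

Going by these compounds, only cyclobutyl and benzyl stand on that oxygen, so it remains open how the number follows the group there. An ethyl or a phenyl group on the oxygen, or a carboxylic acid at the carbonyl carbon, would show whether the ester trend holds beyond these compounds.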